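This account rests on a few compounds, and the source may have more. Where it says the series, first, only, none or still open, it means among the compounds named here.

Compound 1 `CCc1ccc(-c2cc(C)n(S(=O)(=O)Oc3ccccc3)n2)cc1` gives 48.1% in a functional assay on the whole organism for inhibition, with Mus musculus as the target, in the writhing test, with stated times of 3 days and 20 min, at a dose of 30 mg/kg by the oral route; on this read-out lower numbers stand for less inhibition and higher numbers for more inhibition at the one dose given (going by the name of the read-out).
Compound 2 `Cc1cccc(-c2cc(C)n(S(=O)(=O)Oc3ccccc3)n2)c1` gives 43.8%.
Compound 3 `Cc1cc(-c2cccc(Cl)c2)nn1S(=O)(=O)Oc1ccccc1` gives 18.9%.

The three compounds share one core and differ only in the aromatic group attached to it. Compound 3 stands lowest of the three: the drop is a number 24.9 percentage points lower from compound 2 to compound 3 (beyond the scatter) and a number 29.2 percentage points lower from compound 1 to compound 3 (beyond the scatter), both beyond the scatter, whereas the step of a number 4.3 percentage points lower from compound 1 to compound 2 (within the scatter) lies within the scatter.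

Compound 4 `Cc1cc(-c2ccccn2)nn1S(=O)(=O)Oc1ccccc1` differs from compound 3 in a single place: pyridin-2-yl in place of 3-chlorophenyl on an aromatic carbon. Among the compounds with values here, none of the measured steps exchanges the whole ring for one carrying a nitrogen, so they bear on this change only loosely. They do show that the group on this aromatic carbon can shift this assay by a modest amount, and that compound 3 has the lowest number of the three groups tried. Within the data shown here, with no direct precedent, a small upward move is expected for compound 4, roughly a number 9.1 percentage points higher from compound 3 to compound 4 (within the scatter), with a wide margin in either direction. For compound 4 the estimate is 28%, expected to fall between 10% and 50%.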

Compound 4, a percentage reported as inhibition, in the whole organism at one dose (the size of the read-out at that dose, not a potency): 15%
For compound 4 the middle estimate is 13 percentage points above the measured one; low and high end bracket the measured number.
By their numbers in this assay, from the lowest: compounds 4 and 3 (each within the scatter of the next); then compounds 2 and 1 (each within the scatter of the next).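

Exchanging 3-chlorophenyl for pyridin-2-yl, which brings a ring nitrogen and a hydrogen-bond acceptor to this aromatic carbon, gives a number 3.9 percentage points lower from compound 3 to compound 4 (within the scatter) in this assay and so does not separate the two groups. The other two new steps are of a different size, a number 28.8 percentage points lower from compound 2 to compound 4 (beyond the scatter) and a number 33.1 percentage points lower from compound 1 to compound 4 (beyond the scatter) and these show that pyridin-2-yl, like 3-chlorophenyl, stands clearly apart from 3-methylphenyl and 4-ethylphenyl, so among these four groups the two rings carrying a methyl or ethyl group hold the higher numbers. Nothing available explains this split or tells what the chloro group and the ring nitrogen might have in common.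

The compounds shown leave open how a plain phenyl group, a pyridin-3-yl or pyridin-4-yl ring, or a phenyl ring carrying a methoxy group or an amine would behave at this carbon, and so whether the place of the nitrogen in the ring matters at all. They also leave open whether a longer chain, such as propyl or butyl on the phenyl ring, would raise the number further, and how the result would look at doses other than the single one used here.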